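From dimethoxyphenyl to bromophenyl in a cytotoxic series

This account rests on a few compounds, and the source may have more. Where it says the series, first, only, none or still open, it means among the compounds named here.

- compound 1 `CN1C/C(=C\c2cccc([N+](=O)[O-])c2)C(=O)/C(=C/c2ccccc2F)C1` gives 3890 nM in cell tests
- compound 2 `COc1cc(/C=C2\CN(C)C/C(=C\c3ccc(C#N)cc3)C2=O)cc(OC)c1` gives 4650 nM in cell tests
- compound 3 `COc1cc(/C=C2\CN(C)C/C(=C\c3cc(OC)c(OC)c(OC)c3)C2=O)cc(OC)c1` gives 3470 nM in cell tests

All three values come from a functional assay on K562 cells (Homo sapiens) for cytotoxicity, read by MTT assay, with a stated time of 24 h (on this read-out higher numbers stand for weaker inhibition and lower numbers for stronger inhibition), and the compounds share one core. Compound 3 stands at 3470 nM and the values of compound 1 and compound 2 both lie within the usual scatter of that number, so the three cannot be ranked.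

The next compound, compound 4 `COc1cc(/C=C2\CN(C)C/C(=C\c3ccc(Br)cc3)C2=O)cc(OC)c1OC`, has not been measured yet. It has 4-bromophenyl in place of 3,5-dimethoxyphenyl on a double-bonded chain carbon bound to a double-bonded ring carbon, and the counted change is 4-bromophenyl in place of 3,5-dimethoxyphenyl on a double-bonded chain carbon bound to a double-bonded ring carbon in full.

For the measured compounds named here, no two measured compounds differ in one place only, which leaves no measured step to judge this swap by. There is only the narrow spread of three compounds with different side groups: compound 1 at 3890 nM and compound 2 at 4650 nM stay close to compound 3. A change beyond the scatter in this assay is therefore not expected, and the estimated move is a 1.1-fold higher number from compound 3 to compound 4 (0.04 log units; within the scatter) without a firm direction. The estimated value for compound 4 is 3800 nM with 1800 nM and 8000 nM as the expected ends of its range.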

Compound 4, half-maximal inhibitory concentration: 12400 nM
Compound 4: middle estimate off by 3.3-fold (0.51 log units), on the low side, outside the stated range (above it).
By their numbers in this assay, from the lowest: compounds 3, 1 and 2 (each within the scatter of the next); then compound 4.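

In this assay, placing 4-bromophenyl where 3,5-dimethoxyphenyl stood, on a double-bonded chain carbon bound to a double-bonded ring carbon, gives a 3.6-fold higher number from compound 3 to compound 4 (0.55 log units; beyond the scatter), which means weaker inhibition. For the compounds shown here, the earlier compounds offered no pair differing in one place and stayed within the scatter of each other, so this is the first sign that the group at this position can shift the read-out, even with the rest of the molecule unchanged. The data hold no measurement that explains the shift, so the counted differences between the two groups, such as the oxygen atoms leaving and the bromine entering, remain a description and not a cause.

This single step cannot separate the loss of the methoxy groups from the arrival of the bromine, and it cannot show whether the bromine itself matters. Also open, on these data alone, is where compounds would fall if this position carried an unsubstituted phenyl, a dimethylamino group on the phenyl or a carboxylic acid on the phenyl, and whether the same swap would have a similar effect on a different partner group elsewhere on the shared core.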